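Silicon substituent swap in a squalene monooxygenase series

The source may report more compounds than this note shows. Statements on the series, on what has been measured and on what is new or still open speak of the compounds shown alone.

For the measured compounds named here, compound 2 `CCN(C/C=C/C#CC(C)(C)C)Cc1cccc(OC[Si](C)(C)c2ccccc2-c2ccsc2)c1` is the weaker of the two measured compounds: in a functional assay on liver (Sus scrofa) for inhibition of squalene monooxygenase (Homo sapiens), using microsomes (on this read-out lower numbers stand for stronger inhibition and higher numbers for weaker inhibition), compound 2 gives 10000 nM, whereas compound 1 `CCN(C/C=C/C#CC(C)(C)C)Cc1cccc(OC[Si](C)(C)c2ccc(C=O)cc2)c1` gives 100 nM, so compound 2 stands at the highest number of the pair, with compound 1 as its only neighbour. The measured step is a 100-fold higher number from compound 1 to compound 2 (2.00 log units; beyond the scatter), which shows that the group carried by the silicon weighs heavily on this read-out. Compound 3 `CCN(C/C=C/C#CC(C)(C)C)Cc1cccc(OC[Si](C)(C)CCc2ccccc2)c1`, not yet measured, differs from compound 2 by phenethyl in place of 2-(thiophen-3-yl)phenyl on a silicon. Going by the values given here, no measured step covers this exact change; the step from compound 1 to compound 2 bears on it only by showing how strongly the silicon substituent can move the number. Since compound 3 carries neither the 4-formylphenyl of compound 1 nor the 2-(thiophen-3-yl)phenyl of compound 2, its number is expected to land between the two, with a step of a 13-fold lower number from compound 2 to compound 3 (1.10 log units; beyond the scatter) toward stronger inhibition. Compound 3 is therefore estimated at 800 nM, within a range from 150 nM to 5000 nM.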

Compound 3, half-maximal inhibitory concentration: > 10000 nM
Compound 3 was reported as a limit (the forecaster's own chance of this, stated with the estimate: 5%); middle value at least 12-fold (1.09 log units) away from the limit.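

Compound 3 is reported in this assay only as a limit: the limit of > 10000 nM in this assay, at which 1 of the 3 values shown sits.

Placing phenethyl in place of 4-formylphenyl on the silicon gives an at least 100-fold higher number from compound 1 to compound 3 (2.00 log units; beyond the scatter). The earlier pair left open whether the loss belonged to the 2-(thiophen-3-yl)phenyl group alone, whereas compound 3 shows that phenethyl, with its single six-membered aromatic ring, no sulfur and fewer heavy atoms, also lies far from compound 1 on this read-out. Exchanging 2-(thiophen-3-yl)phenyl for phenethyl gives a number no lower from compound 2 to compound 3 (the limit leaves the size open), so these two groups cannot be put in order.

Among the three groups shown on the silicon, 4-formylphenyl gives the lowest number, as a 100-fold higher number from compound 1 to compound 2 (2.00 log units; beyond the scatter) also shows, and the compounds shown do not tell whether the formyl group or the aromatic ring carrying it matters more. A plain phenyl on the silicon, or a nitrile or a hydroxymethyl group in place of the formyl, would bear on that question directly.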